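Phosphate step on the phenol oxygen: compound 2 to compound 4

The compounds below may be only part of what the source reports. "The series", "measured", "known", "first", "only" and "open" are said of these compounds alone.

Measured so far in a functional assay on IGROV-1 cells (Homo sapiens) for antiproliferative activity (a higher number here means a weaker inhibitor, a lower number a stronger inhibitor), for this series:
- compound 1 `COc1cc(/C=C\Cc2cc(O)c3ccsc3c2)cc(OC)c1OC` gives 280 nM
- compound 2 `COc1cc(/C=C\Cc2cc(O)c3ccoc3c2)cc(OC)c1OC` gives 110 nM
- compound 3 `COc1cc(/C=C\Cc2cc(OP(=O)(O)O)c3ccsc3c2)cc(OC)c1OC` gives 1610 nM

Among these three, compound 2 gives the lowest number, 110 nM in this assay and its gaps to the other two lie beyond the scatter. Compound 1 is nearest to it and compound 3 furthest.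

The next entry is compound 4 `COc1cc(/C=C\Cc2cc(OP(=O)(O)O)c3ccoc3c2)cc(OC)c1OC` and the change from compound 2 is a group of 4 heavy atoms (3 oxygen, 1 phosphorus; no ring) in place of a hydrogen atom, on an oxygen on an aromatic ring with a group of 4 heavy atoms (3 oxygen, 1 phosphorus; no ring) in place of a hydrogen atom, on an oxygen on an aromatic ring.

Within the data shown here, one measured step bears on this. The same replacement on the core of compound 1 gives a 5.8-fold higher number from compound 1 to compound 3 (0.76 log units; beyond the scatter) and that modest change lies beyond the scatter. Among the measured compounds shown here, no second pair shows whether its size carries over to the core of compound 2, so the expectation rests on this single pair. A step of similar size and the same direction is expected in this assay for this replacement. The estimated change is a 5.8-fold higher number from compound 2 to compound 4 (0.76 log units; beyond the scatter) towards a higher number. For compound 4 the expected value is 640 nM with an estimated range from 270 nM to 1500 nM at its two ends.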

Compound 4, half-maximal inhibitory concentration: 680 nM
For compound 4 the middle estimate is 1.1-fold (0.03 log units) below the measured one; measured number inside the range.
By their numbers in this assay, from the lowest: compound 2; then compound 1; then compound 4; then compound 3.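

In this assay, a group of 4 heavy atoms (3 oxygen, 1 phosphorus; no ring) in place of a hydrogen atom, on an oxygen on an aromatic ring, again raises the number, with a 6.2-fold higher number from compound 2 to compound 4 (0.79 log units; beyond the scatter). The penalty for this change at this position is therefore no longer tied to one core, and its size holds across the two cores shown: the same change on two cores in this assay, a 5.8-fold higher number (0.76 log units; beyond the scatter) from compound 1 to compound 3 and a 6.2-fold higher number (0.79 log units; beyond the scatter) from compound 2 to compound 4, 1.1-fold (0.03 log units) apart, within the scatter of two such steps. The order of the two cores also survives the change on the printed values, since compound 2 at 110 nM stands below compound 1 at 280 nM, and compound 4 at 680 nM stands below compound 3 at 1610 nM.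

Two pairs on two closely related cores do not establish how the step behaves on a third core, or on a core with a different chain or a different substitution on the trimethoxy-bearing ring. Also open, as far as these compounds go, is how other groups on this same oxygen compare with the free hydroxyl compounds, for example a methyl ether, an acetate ester or a glycine ester.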